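The isopropylamino group of compound 3 exchanged for a carbinol

The compounds below may be only part of what the source reports. "The series", "measured", "known", "first", "only" and "open" are said of these compounds alone.

Among the three measured compounds, compound 3 `Cc1noc(NS(=O)(=O)c2cccc3c(NC(C)C)cccc23)c1C` gives the lowest number in an assay on VSM-A10 cells for antagonist activity at Endothelin-1 receptor (Rattus norvegicus) (a lower number here means a stronger inhibitor, a higher number a weaker inhibitor), at 20 nM. Compound 1 `Cc1noc(NS(=O)(=O)c2cccc3c(N4CCCCC4=O)cccc23)c1C` gives 270 nM in this assay, and compound 2 `Cc1noc(NS(=O)(=O)c2cccc3c(CN(C)C)cccc23)c1C` gives 2800 nM. Both steps that lead to compound 3 are large and beyond the scatter: a 14-fold lower number from compound 1 to compound 3 (1.13 log units; beyond the scatter) and a 140-fold lower number from compound 2 to compound 3 (2.15 log units; beyond the scatter). Between the other two compounds, a 10-fold higher number from compound 1 to compound 2 (1.02 log units; beyond the scatter).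

Compound 4 `Cc1noc(NS(=O)(=O)c2cccc3c(C(C)(C)O)cccc23)c1C` arises from compound 3 by a single change: 1-hydroxy-1-methylethyl in place of isopropylamino on an aromatic carbon. Among the compounds with values here, none of the measured steps exchanges isopropylamino for a group of this kind, so the measured steps bear on it only indirectly. What they show is that each of the two other groups measured on this carbon gives a markedly higher number than isopropylamino, by the sizes of a 14-fold lower number from compound 1 to compound 3 (1.13 log units; beyond the scatter) and a 140-fold lower number from compound 2 to compound 3 (2.15 log units; beyond the scatter) read in the opposite direction. The expectation is therefore that leaving isopropylamino raises the number again, by a step of about a 15-fold higher number from compound 3 to compound 4 (1.18 log units; beyond the scatter), with considerable uncertainty about its size. Compound 4 is estimated to give about 300 nM in this assay, with a likely range from 60 nM to 1500 nM.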

Compound 4, half-maximal inhibitory concentration: 2890 nM
Beside the measured number, compound 4's estimate is 9.6-fold (0.98 log units) below it; measured number above the stated range.
By their numbers in this assay, from the lowest: compound 3; then compound 1; then compounds 2 and 4 (each within the scatter of the next).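

Exchanging isopropylamino for 1-hydroxy-1-methylethyl leaves the counts of heavy atoms, hydrogen-bond donors and hydrogen-bond acceptors in the group unchanged, yet it gives a 140-fold higher number from compound 3 to compound 4 (2.16 log units; beyond the scatter) and so those counts alone do not account for the low number of compound 3. The new compound also sorts the groups on this aromatic carbon by the atom that joins them to it: a 1.0-fold higher number from compound 2 to compound 4 (0.01 log units; within the scatter) places the two carbon-linked groups within the scatter of each other, while an 11-fold higher number from compound 1 to compound 4 (1.03 log units; beyond the scatter) and the step to compound 3 above set both apart from the nitrogen-linked groups, and none of the four compounds goes against this. Nothing among the data available here explains the size of the step.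

The compounds shown leave open whether the linking nitrogen or the amine hydrogen of isopropylamino matters more, a question that an N-methyl-N-isopropylamino group and an isopropoxy group on this carbon could separate. They also leave open how the number responds to the alkyl part of the amine, as with a cyclopropylamino group or a longer chain such as n-butylamino.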